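The source may report more compounds than this note shows. Statements on the series, on what has been measured and on what is new or still open speak of the compounds shown alone.

Compound 1 `COc1cc2ncnc(Nc3cc(O)[nH]n3)c2cc1OC`: < 100000 nM
Compound 2 `COc1cc2ncnc(Nc3cc(-c4ccccc4)[nH]n3)c2cc1OC`: < 100000 nM

Both entries come from a functional assay on ZR-75-30 cells (Homo sapiens) for cytotoxicity, read by MTT assay (on this read-out lower numbers stand for stronger inhibition and higher numbers for weaker inhibition), and neither is a number. On these data alone, for compound 1 the entry is a limit of the assay, so its place on the scale stays open. For compound 2 the entry is a limit as well. All that the series offers so far is the limit of < 100000 nM in this assay, at which 2 of the 2 values shown sit.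

Compound 3 `COc1ccc(-c2cc(Nc3ncnc4cc(OC)c(OC)cc34)n[nH]2)cc1` keeps the core of compound 1 and differs in one place: 4-methoxyphenyl in place of hydroxy on an aromatic carbon. The nearest measured change is phenyl in place of hydroxy on an aromatic carbon, a step that the two limits leave unreadable from compound 1 to compound 2. That step has no readable size to carry over, so it points in no direction, and no step beyond the scatter can be argued for this assay. The estimate therefore stays wide and rests on (the limit of < 100000 nM in this assay, at which 2 of the 2 values shown sit). The estimated step is a step that the limit leaves unreadable from compound 1 to compound 3, and little weight should be placed on it. For compound 3 the expected value is 30000 nM, with an estimated range from 6000 nM to 100000 nM.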

Compound 3, half-maximal inhibitory concentration: < 100000 nM
Compound 3 was reported as a limit (the forecaster's own chance of this, stated with the estimate: 50%); the middle value does not contradict the limit.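

In this assay compound 3 gives < 100000 nM, which is a limit of the assay and not a number. No step can be read from compound 1 or compound 2 to compound 3. The compounds shown leave open how compound 1, compound 2 and compound 3 rank against one another, with the series resting only on this: the limit of < 100000 nM in this assay, at which 3 of the 3 values shown sit.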